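From 4-fluorophenyl to (4-chlorophenyl)amino on a carbonyl carbon

A few compounds are considered here, and "the series" means these few. Any claim that something is new, unique, unknown or untested is made for them only; others in the source may bear on it.

In a functional assay on HT-29 cells (Homo sapiens) for inhibition, read by MTT assay, with a stated time of 48 h (on this read-out lower numbers stand for stronger inhibition and higher numbers for weaker inhibition), compound 1 `COc1ccc(-n2c(SCc3ccccc3)nnc2-c2cc(OC)c(OC)c(OC)c2)cc1` gives > 60000 nM, which is a limit of the assay and not a number. Within the data shown here, compound 2 `COc1ccc(-n2c(SCC(=O)c3ccc(F)cc3)nnc2-c2cc(OC)c(OC)c(OC)c2)cc1` gives 42500 nM, the only actual number available so far.

Compound 3 `COc1ccc(-n2c(SCC(=O)Nc3ccc(Cl)cc3)nnc2-c2cc(OC)c(OC)c(OC)c2)cc1` differs from compound 2 in one place: (4-chlorophenyl)amino in place of 4-fluorophenyl on a carbonyl carbon. In plain terms, (4-chlorophenyl)amino stands in place of 4-fluorophenyl on a carbonyl carbon, and the new group brings a hydrogen-bond donor.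

Among the measured compounds shown here, only one measured step offers any guidance: an at least 1.4-fold lower number from compound 1 to compound 2 (0.14 log units; that floor lies within the scatter). That step is a different structural change, so it cannot fix the size of this one. Its small size gives no reason to expect a large move, so no step beyond the scatter is expected in this assay, with only a slight lean towards a lower number. Compound 3 could also end up at the limit of > 60000 nM in this assay, at which 1 of the 2 values shown sits.

The expected change is a 1.4-fold lower number from compound 2 to compound 3 (0.15 log units; within the scatter). For compound 3 the estimated value is 30000 nM, with an expected range of 7000 nM to 60000 nM.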

Compound 3, half-maximal inhibitory concentration: 58000 nM
Estimate against measurement, compound 3: 1.9-fold (0.29 log units) below, within the range that was stated.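

In this assay, putting (4-chlorophenyl)amino in place of 4-fluorophenyl on a carbonyl carbon gives a 1.4-fold higher number from compound 2 to compound 3 (0.14 log units; within the scatter), so this change, which brings a hydrogen-bond donor and exchanges fluorine for chlorine, does not separate the two compounds on this read-out. Replacing phenyl on a saturated chain carbon bound to a sulfur with (4-chlorophenyl)carbamoyl gives an at least 1.0-fold lower number from compound 1 to compound 3 (0.01 log units; that floor lies within the scatter), which is only a floor and shows no step beyond the scatter. Compound 1 carries a limit of the assay and not a number: the limit of > 60000 nM in this assay, at which 1 of the 3 values shown sits.

As far as these compounds go, the exchange of fluorine for chlorine and the arrival of the amino nitrogen come together in one step, so their separate contributions stay open, and (4-fluorophenyl)amino on the same carbonyl carbon would tell them apart. Also open, from the compounds shown here alone, is whether a different kind of group on that carbonyl carbon, such as a morpholine amine or a longer chain ending in a carboxylic acid, would give a number clearly lower than those of compound 2 and compound 3.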